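Chain extension on the shared core: compound 3

The compounds below may be only part of what the source reports. "The series", "measured", "known", "first", "only" and "open" are said of these compounds alone.

Compound 1 `CCCCCCCCOc1cc(OC)ccc1C(C)=O` gives 38300000 nM
Compound 2 `CCCCCCCCCCOc1cc(OC)ccc1C(C)=O` gives 41700000 nM

Both values come from a functional assay, read by spectrophotometry, with a stated time of 6 min (on this read-out lower numbers stand for stronger inhibition and higher numbers for weaker inhibition), and lie within the scatter of each other, so no order can be read between compound 2 and compound 1. Compound 3 `CCCCCCCCCCCCOc1cc(OC)ccc1C(C)=O` has not yet been measured. It differs from compound 2 by one change: ethyl in place of hydrogen on a saturated chain carbon, ten or more bonds along the chain from an oxygen on an aromatic ring.

For the measured compounds named here, one measured step bears on this, the same replacement of hydrogen by ethyl: a 1.1-fold higher number from compound 1 to compound 2 (0.04 log units; within the scatter). That step stays within the scatter. It is a single step, so it establishes no trend, and the data do not show whether the chain can grow further without a change in the read-out. No step beyond the scatter is therefore expected in this assay for the new extension, in either direction. The estimated step is a 1.1-fold higher number from compound 2 to compound 3 (0.03 log units; within the scatter) and it is expected to remain within the scatter. Compound 3 is expected at 45000000 nM with an estimated range of 24000000 nM to 85000000 nM on this read-out.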

Compound 3, half-maximal inhibitory concentration: 40700000 nM
Estimate against measurement, compound 3: 1.1-fold (0.04 log units) above, within the range that was stated.
By their numbers in this assay, from the lowest: compounds 1, 3 and 2 (each within the scatter of the next).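

In this assay, the extension now has a second reading: ethyl in place of hydrogen on a saturated chain carbon, ten or more bonds along the chain from an oxygen on an aromatic ring, gives a 1.0-fold lower number from compound 2 to compound 3 (0.01 log units; within the scatter). The larger change in chain length gives a 1.1-fold higher number from compound 1 to compound 3 (0.03 log units; within the scatter), so even the two chains furthest apart in length among compound 1, compound 2 and compound 3 are not separated by this read-out, and no order can be drawn among the three. No measurement is at hand that bears on why the read-out stays flat along this chain.

The compounds shown leave open whether a chain shorter than that of compound 1, or longer than that of compound 3, would also stay within the scatter in this assay. They also leave open whether an amine or a carboxylic acid on a saturated chain carbon would move the number on the shared core.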